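This account rests on a few compounds, and the source may have more. Where it says the series, first, only, none or still open, it means among the compounds named here.

Notes on the series.

Compound 1 `Cc1cccc(S(=O)(=O)N2CCC(N3CCC(C)CC3)CC2)c1` carries 3-methylphenyl on the sulfonyl sulfur. In an ADME assay on HCT-116 cells (Homo sapiens) for cytotoxicity, read by CellTiter-Glo, with a stated time of 72 h (a lower number here means a stronger inhibitor, a higher number a weaker inhibitor), compound 1 gives > 5000 nM, which is a limit of the assay and not a number. Compound 2 `CC1CCN(C2CCN(S(=O)(=O)c3ccc(F)cc3F)CC2)CC1` has 2,4-difluorophenyl in place of 3-methylphenyl on the sulfonyl sulfur. In this assay compound 2 gives > 5000 nM, again a limit rather than a number. The step that the two limits leave unreadable from compound 1 to compound 2 is therefore unreadable, since both values sit at the limit of > 5000 nM in this assay, at which 2 of the 2 values shown sit; compound 1 stands only at that limit, with no firmer number around it.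

Compound 3 `CC1CCN(C2CCN(S(=O)(=O)c3cccc(-c4ccccc4)c3)CC2)CC1` differs from compound 1 by phenyl in place of methyl on an aromatic carbon. Going by the values given here, no measured step covers a change of this kind, and the one step measured, from compound 1 to compound 2, gives no size because the limit of > 5000 nM in this assay, at which 2 of the 2 values shown sit, holds both of its ends. The expectation is accordingly no step beyond the scatter, with another limit the most likely outcome. For compound 3 the estimated value is 8000 nM, expected to lie between 2000 nM and 30000 nM. This estimate implies a step that the limit leaves unreadable from compound 1 to compound 3 that is expected to stay within the scatter.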

Compound 3, half-maximal inhibitory concentration: > 5000 nM
Compound 3: only a limit was reported (the forecaster's own chance of this, stated with the estimate: 70%); the middle value does not contradict the limit.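

In this assay compound 3 gives > 5000 nM, a limit of the assay and not a number. No step can be read from compound 1 to compound 3: the limit of > 5000 nM in this assay, at which 3 of the 3 values shown sit.

The compounds shown leave open whether phenyl in place of methyl, or 2,4-difluorophenyl in place of 3-methylphenyl, changes cytotoxicity at all.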